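This account rests on a few compounds, and the source may have more. Where it says the series, first, only, none or still open, it means among the compounds named here.

Compound 1 `COc1nc(-c2cccc(Cl)c2)ccc1[C@@H](c1ccccc1)[C@@](O)(CCN(C)C)c1cccc2ccccc12`: > 50 ug/mL (a limit)
Compound 2 `COc1nc(C2CCCCC2)ccc1[C@@H](c1ccccc1)[C@@](O)(CCN(C)C)c1cccc2ccccc12`: 32.3 ug/mL
Compound 3 `COc1nc(-c2ccsc2)ccc1[C@@H](c1ccccc1)[C@@](O)(CCN(C)C)c1cccc2ccccc12`: 24.4 ug/mL

In a toxicity assay on Vero cells (Chlorocebus sabaeus) for cytotoxicity (on this read-out higher numbers stand for lower toxicity in this test and lower numbers for higher toxicity in this test), the two actual numbers lie within the scatter of each other: a 1.3-fold lower number from compound 2 to compound 3 (0.12 log units; within the scatter). Only the limit stands clearly apart: an at least 2.0-fold lower number from compound 1 to compound 3 (0.31 log units; beyond the scatter). Compound 4 `COc1nc(-c2ccc(C(F)(F)F)cc2)ccc1[C@@H](c1ccccc1)[C@@](O)(CCN(C)C)c1cccc2ccccc12` brings (4-(trifluoromethyl)phenyl in place of thiophen-3-yl on an aromatic carbon), that is, 4-(trifluoromethyl)phenyl in place of thiophen-3-yl on an aromatic carbon. Among the compounds with values here, the closest precedent is the 3-chlorophenyl of compound 1, seen in the reverse direction in that same step. The other floor, an at least 1.5-fold lower number from compound 1 to compound 2 (0.18 log units; that floor lies within the scatter), is weaker evidence. A modest rise is therefore expected, though with little certainty. The expected change is a 1.6-fold higher number from compound 3 to compound 4 (0.21 log units; within the scatter). For compound 4 the estimated value is 40 ug/mL, within a range of 20 ug/mL to 80 ug/mL.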

Compound 4, half-maximal cytotoxic concentration: > 50 ug/mL
Compound 4: no number, only a limit; the forecaster's own chance of this, stated with the estimate: 40%; at least 1.2-fold (0.09 log units) between middle value and limit.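

In this assay, 4-(trifluoromethyl)phenyl next to the ring nitrogen gives an at least 2.0-fold higher number from compound 3 to compound 4 (0.31 log units; beyond the scatter), while the same group in place of cyclohexyl gives an at least 1.5-fold higher number from compound 2 to compound 4 (0.18 log units; that floor lies within the scatter). Until now only the 3-chlorophenyl of compound 1 stood at a limit, and compound 4 shows that a second substituted phenyl group does as well. The step from compound 1 to compound 4 cannot be read because both values are limits: the limit of > 50 ug/mL in this assay, at which 2 of the 4 values shown sit.

Any ranking of these two phenyl groups remains open. So does whether an amine or a carboxylic acid on the phenyl ring would keep the value at this limit.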